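Nitro for Bromo in a Series Stuck at the Limit

A few compounds are considered here, and "the series" means these few. Any claim that something is new, unique, unknown or untested is made for them only; others in the source may bear on it.

Measured in a functional assay on RH7777 cells (Homo sapiens) for antiproliferative activity against RH7777 (Rattus norvegicus), read by sulforhodamine B assay; a higher number here means a weaker inhibitor, a lower number a stronger inhibitor:
compound 1, `CCCCCCCCCCCCCCCCCCNC(=O)[C@H]1CSC(c2c[nH]c3ccccc23)N1`, gives > 20000 nM, which is a limit of the assay and not a number.
compound 2, `CCCCCCCCCCCCCCCCCCNC(=O)[C@H]1CSC(c2ccc(Br)cc2)N1`, gives > 20000 nM, also a limit of the assay.

Compound 2 therefore stands at the top of the range the assay can report, where both measured values sit (the limit of > 20000 nM in this assay, at which 2 of the 2 values shown sit). Within the data shown here, the only measured step, a step that the two limits leave unreadable from compound 1 to compound 2, cannot be sized: both of its ends are limits, so it tells neither direction nor magnitude.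

Compound 3, `CCCCCCCCCCCCCCCCCCNC(=O)[C@H]1CSC(c2ccc([N+](=O)[O-])cc2)N1`, differs from compound 2 by nitro in place of bromo on an aromatic carbon. Among the measured compounds shown here, the one measured step is the only evidence that bears on this change, and since its size is unreadable, no measured step supports an expectation of movement in either direction beyond the scatter. The estimate for compound 3 therefore rests on where compound 2 stands, and the expected step is a number no higher from compound 2 to compound 3 (the limit leaves the size open), with a further limit the most likely outcome. Compound 3 is estimated at 20000 nM, within a range from 5000 nM to 80000 nM.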

Compound 3, half-maximal inhibitory concentration: about 20000 nM
Beside the measured number, compound 3's estimate shows no gap at the digits printed; low and high end bracket the measured number.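

In this assay, among these compounds, compound 3 gives about 20000 nM, the only actual number among the three compounds, so 4-nitrophenyl at this position yields a readable value where the 4-bromophenyl and 1H-indol-3-yl compounds did not, with a number no higher from compound 2 to compound 3 (the limit leaves the size open) and with a number no higher from compound 1 to compound 3 (the limit leaves the size open) as the only steps to it. Compound 2 gives > 20000 nM, which is a limit of the assay. The steps to compound 3 from compound 1 and from compound 2 cannot be read for size, so nitro in place of bromo may be a small change or a large one, and compound 3 stands right at the edge of what the assay reports: the limit of > 20000 nM in this assay, at which 2 of the 3 values shown sit.

From the compounds shown here alone, what stays open is whether any group on this aromatic carbon can bring a value well clear of that limit, and an amine or a carboxylic acid in place of the nitro would be one way to test this. Going by these compounds, all three compounds also share the same long chain on the amide, so the effect of a shorter chain there remains unknown.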